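Chloro in place of hydrogen in a series at the limit

This account rests on a few compounds, and the source may have more. Where it says the series, first, only, none or still open, it means among the compounds named here.

Compound 1 `Cc1cc(Nc2cc(Cl)cc(S(F)(F)(F)(F)F)c2)nc(N)n1` gives, in an assay on cells for inhibition of S-adenosylmethionine decarboxylase proenzyme (Homo sapiens), read by mass spectrometry, at pH 7.2 (a lower number here means a stronger inhibitor, a higher number a weaker inhibitor), the value > 180000 nM, which is a limit of the assay and not a number.
Compound 2 `Cc1cc(Nc2cccc(S(F)(F)(F)(F)F)c2)nc(N)n1` gives in this assay the value > 180000 nM, again a limit.
Compound 3 `Cc1cc(Nc2ccccc2C)nc(N)n1` gives in this assay the value > 180000 nM, also a limit.

The difference between the cores of compound 3 and compound 2 is not broken down here. Compound 1 arises from compound 2 by the change (chloro in place of hydrogen on an aromatic carbon). Its step is a step that the two limits leave unreadable from compound 2 to compound 1, and this is so because of the limit of > 180000 nM in this assay, at which 3 of the 3 values shown sit: both ends of the step are limits, so its size cannot be read.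

Compound 4 `Cc1cc(Nc2cc(Cl)ccc2C)nc(N)n1`, not yet measured, arises from compound 3 by the change (chloro in place of hydrogen on an aromatic carbon). This is the same kind of change as that from compound 2 to compound 1, but not the same: in compound 1 the chloro sits meta to a group of 6 heavy atoms and meta to a group of 9 heavy atoms, whereas in compound 4 it sits meta to a group of 9 heavy atoms and para to a methyl group.

For the measured compounds named here, for compound 4 in this assay the step that the limit leaves unreadable from compound 3 to compound 4 is expected to be small, since the only measured example of this kind of change, from compound 2 to compound 1, left both compounds at the limit of the assay. The estimate for compound 4 in this assay is therefore 300000 nM, expected to lie between 90000 nM and 1000000 nM, most likely reported again only as a limit.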

Compound 4, half-maximal inhibitory concentration: > 180000 nM
Compound 4: only a limit was reported; the forecaster's own chance of this, stated with the estimate: 85%; the middle value lies beyond the limit too.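

Compound 4 gives > 180000 nM in this assay, which is again a limit and not a number. No step can be read from compound 3 to compound 4, because both ends of the comparison are limits: the limit of > 180000 nM in this assay, at which 4 of the 4 values shown sit.

The compounds shown leave open whether chloro in place of hydrogen on an aromatic carbon changes inhibition at all, and how strongly any of them inhibits.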